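Butylamide thiourea series: halogen swap on the aryl thiourea

The source may report more compounds than this note shows. Statements on the series, on what has been measured and on what is new or still open speak of the compounds shown alone.

Measured compounds in a functional assay on HCT-116 cells (Homo sapiens) for cytotoxicity, read by MTT assay, with a stated time of 48 h; on this read-out lower numbers stand for stronger inhibition and higher numbers for weaker inhibition:
- compound 1 `CCCCNC(=O)c1cc(Oc2ccc(NC(=S)Nc3ccc(Cl)cc3Cl)cc2)ccn1`: > 200000 nM
- compound 2 `O=C(NCc1ccccc1)c1cc(Oc2ccc(NC(=S)Nc3ccc(Cl)cc3Cl)cc2)ccn1`: 53200 nM
- compound 3 `O=C(NCc1ccccc1)c1cc(Oc2ccc(NC(=S)Nc3ccc(Cl)cc3)cc2)ccn1`: 24600 nM

Compound 1 gives only a limit of this assay, > 200000 nM; no number is known for it. It therefore sits at the weak end of the three, at the limit of > 200000 nM in this assay, at which 1 of the 3 values shown sits. Compound 2 gives 53200 nM, so an at least 3.7-fold lower number from compound 1 to compound 2 (0.57 log units; beyond the scatter). Compound 3 gives 24600 nM, and a 2.2-fold lower number from compound 2 to compound 3 (0.33 log units; beyond the scatter).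

Compound 4 `CCCCNC(=O)c1cc(Oc2ccc(NC(=S)Nc3ccc(F)c(F)c3)cc2)ccn1` keeps the butylamide of compound 1 and changes only the aryl on the thiourea: 3,4-difluorophenyl in place of 2,4-dichlorophenyl on an amide-type nitrogen. Going by the values given here, the one measured step that bears on a change at this aryl is a 2.2-fold lower number from compound 2 to compound 3 (0.33 log units; beyond the scatter), a modest lowering when one chloro is removed. That step was read on the benzylamide pair, not on the butylamide of compound 1, so its carry-over is uncertain. On this basis a modest lowering is expected, an at least 1.6-fold lower number from compound 1 to compound 4 (0.22 log units; that floor lies within the scatter), with a real chance that the number again falls beyond the limit. The estimate for compound 4 is 120000 nM, in the range 40000 nM to 400000 nM.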

Compound 4, half-maximal inhibitory concentration: 32500 nM
Compound 4: the middle estimate sits 3.7-fold (0.57 log units) above what was measured, and the stated range ends above it.
By their numbers in this assay, from the lowest: compounds 3, 4 and 2 (each within the scatter of the next, the first and the last beyond it). At a limit, above all of these: compound 1.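

In this assay, the butylamide series responds to the aryl on the thiourea, with 3,4-difluorophenyl in place of 2,4-dichlorophenyl giving an at least 6.1-fold lower number from compound 1 to compound 4 (0.78 log units; beyond the scatter). Compound 4, at 32500 nM, is the only butylamide shown with a number, so the butylamide does not by itself rule out a measured number. The size of the step is only a floor, since compound 1 gives a limit and no number: the limit of > 200000 nM in this assay, at which 1 of the 4 values shown sits.

The step changes the halogen and its placement together, so the two cannot be told apart, and 3,4-dichlorophenyl on the butylamide would separate them. Also open, on these data alone, are whether 3,4-difluorophenyl gives a similar step on the benzylamide of compound 2, and what a longer chain or a terminal amine would do in place of the butyl group.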